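A few compounds are considered here, and "the series" means these few. Any claim that something is new, unique, unknown or untested is made for them only; others in the source may bear on it.

Measured in a functional assay on HCT-15 cells (Homo sapiens) for antiproliferative activity, read by sulforhodamine B assay; a lower number here means a stronger inhibitor of growth, a higher number a weaker inhibitor of growth:
- compound 1 `CCCCCCOc1cccc(O)c1C(=O)/C=C/c1ccc(O)cc1`: > 30000 nM (a limit)
- compound 2 `CC(C)=CCOc1cccc(O)c1C(=O)/C=C/c1ccc(O)cc1`: > 30000 nM (a limit)
- compound 3 `O=C(/C=C/c1ccc(O)cc1)c1c(O)cccc1OCC1CCCC1`: 3410 nM

For the measured compounds named here, compound 3 holds the only true number of the three, and the other two entries sit at the limit of > 30000 nM in this assay, at which 2 of the 3 values shown sit. The next compound, compound 4 `CCCCOc1cccc(O)c1C(=O)/C=C/c1ccc(O)cc1`, keeps the shared core and changes one group: propyl in place of cyclopentyl on a saturated chain carbon bound to an oxygen on an aromatic ring. Propyl stands in place of cyclopentyl, so the ring is lost.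

Going by the values given here, two measured steps bear on this change: an at least 8.7-fold lower number from compound 1 to compound 3 (0.94 log units; beyond the scatter), and an at least 8.7-fold lower number from compound 2 to compound 3 (0.94 log units; beyond the scatter). In both, the compound carrying cyclopentyl has the lower number, and both partners lack that ring. The step that the two limits leave unreadable from compound 1 to compound 2 adds nothing. Among the compounds with values here, no measured compound shows the effect of chain length alone, and compound 4 has a shorter chain than compound 1, so the loss may be incomplete.

The expected change is a 4.1-fold higher number from compound 3 to compound 4 (0.61 log units; beyond the scatter), towards weaker growth inhibition. For compound 4 the estimated value is 14000 nM, with an expected range of 4500 nM to 30000 nM.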

Compound 4, concentration for 50% growth inhibition: > 30000 nM
Compound 4: only a limit was reported; the forecaster's own chance of this, stated with the estimate: 45%; middle value at least 2.1-fold (0.33 log units) away from the limit.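

In this assay, propyl in place of cyclopentyl on a saturated chain carbon bound to an oxygen on an aromatic ring gives an at least 8.7-fold higher number from compound 3 to compound 4 (0.94 log units; beyond the scatter), so the shorter open chain joins pentyl and 2-methylprop-1-en-1-yl in falling short of the ring, and chain length in this pair of open chains shows no recovery of growth inhibition. For compound 4 the entry > 30000 nM is a limit and not a number. The steps among compounds 1, 2 and 4 cannot be read, and these three open groups stay unordered, with compound 3 the one ring-bearing member and the one true number: the limit of > 30000 nM in this assay, at which 3 of the 4 values shown sit.

On these data alone, whether the ring itself or its carbon count matters at this place stays open, and a cyclobutyl, a cyclohexyl or a branched chain such as isobutyl would bear on that. As far as these compounds go, compound 3 gives 3410 nM, and how much stronger growth inhibition could become from there also stays open.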